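Adding bromo to the phenyl of compound 2

A few compounds are considered here, and "the series" means these few. Any claim that something is new, unique, unknown or untested is made for them only; others in the source may bear on it.

- compound 1 `CC1(C)[C@H]2CC[C@]1(C)N(Cc1cn(-c3ccccc3F)nn1)C(=O)C2`: 300 nM
- compound 2 `CC1(C)[C@H]2CC[C@]1(C)N(Cc1cn(-c3ccccc3)nn1)C(=O)C2`: 240 nM

Both values come from a functional assay on SGC-7901 cells (Homo sapiens) for inhibition, read by MTT assay, with a stated time of 24 h; a lower number here means a stronger inhibitor, a higher number a weaker inhibitor. Among the measured compounds shown here, compound 2 lies within the usual scatter of compound 1, the only other compound measured, so the two cannot be told apart. The next compound, compound 3 `CC1(C)[C@H]2CC[C@]1(C)N(Cc1cn(-c3cccc(Br)c3)nn1)C(=O)C2`, turns the phenyl into 3-bromophenyl, with bromo in place of hydrogen on an aromatic carbon, meta to a large group: bromo in place of hydrogen on an aromatic carbon. For the measured compounds named here, only one measured step bears on this change: a 1.3-fold lower number from compound 1 to compound 2 (0.10 log units; within the scatter). That step also swaps a hydrogen and a halogen on the aromatic ring, but the halogen there is fluoro, so it is only a rough guide. On that limited evidence, no step beyond the scatter is expected in this assay. The estimated change is a 1.1-fold lower number from compound 2 to compound 3 (0.04 log units; within the scatter). For compound 3 the expected value is 220 nM, with an estimated range from 90 nM to 550 nM.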

Compound 3, half-maximal inhibitory concentration: 120 nM
Compound 3: middle estimate off by 1.8-fold (0.26 log units), on the high side, within the range that was stated.
By their numbers in this assay, from the lowest: compounds 3, 2 and 1 (each within the scatter of the next, the first and the last beyond it).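

In this assay, putting bromo on the phenyl gives a step that still cannot be told from the scatter (a 2.0-fold lower number from compound 2 to compound 3 (0.30 log units; within the scatter)), so this single change has no clear effect at this place on the ring. Among the compounds shown here, the comparison of the two halogen-bearing rings does separate, though only modestly (a 2.5-fold lower number from compound 1 to compound 3 (0.40 log units; beyond the scatter)), and it is the first difference beyond the scatter in this small set. Nothing measured here explains that difference.

The compounds shown leave open whether that gap follows from the kind of halogen or from its place on the ring, since 2-fluorophenyl and 3-bromophenyl differ in both. They also leave open how an amine or a carboxylic acid would read in place of bromo on the same ring carbon.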